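A few compounds are considered here, and "the series" means these few. Any claim that something is new, unique, unknown or untested is made for them only; others in the source may bear on it.

Compound 1 `NC(=O)c1c(NC(=O)c2ccccc2Cl)sc2c1CCN(Cc1ccccc1)C2`: 14500 nM
Compound 2 `NC(=O)c1c(NC(=O)c2ccccc2Cl)sc2c1CCN(C(=S)Nc1ccccc1Br)C2`: 10800 nM
Compound 3 `NC(=O)c1c(NC(=O)c2ccccc2Cl)sc2c1CCN(C(=O)Nc1c(Cl)cccc1Cl)C2`: 24400 nM

All three were tested in a functional assay on MKN-74 cells (Homo sapiens) for antiproliferative activity, with a stated time of 24 h; a higher number here means a weaker inhibitor, a lower number a stronger inhibitor. Compound 2 shows the lowest number of the three: the step of a 1.3-fold lower number from compound 1 to compound 2 (0.13 log units; within the scatter) is within the scatter, while a 2.3-fold higher number from compound 2 to compound 3 (0.35 log units; beyond the scatter) is just beyond it. Compound 4 `NC(=O)c1c(NC(=O)c2ccccc2Br)sc2c1CCN(C(=S)Nc1ccccc1Br)C2` differs from compound 2 in one atom: bromo in place of chloro on an aromatic carbon. For the measured compounds named here, none of the measured steps touches this part of the molecule; a 1.3-fold lower number from compound 1 to compound 2 (0.13 log units; within the scatter), a 1.7-fold higher number from compound 1 to compound 3 (0.23 log units; within the scatter) and a 2.3-fold higher number from compound 2 to compound 3 (0.35 log units; beyond the scatter) all alter the group on the ring nitrogen, and all were small. A step of comparable smallness is therefore expected in this assay, with no change beyond the scatter, an expected step of a 1.1-fold lower number from compound 2 to compound 4 (0.03 log units; within the scatter). Compound 4 is estimated at 10000 nM, with a range from 4000 nM to 25000 nM.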

Compound 4, half-maximal inhibitory concentration: 13700 nM
Estimate against measurement, compound 4: 1.4-fold (0.14 log units) below, and the stated range covers the measured number.
By their numbers in this assay, from the lowest: compounds 2, 4, 1 and 3 (each within the scatter of the next, the first and the last beyond it).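

For the compounds shown here, the earlier compounds differ only in the group on the ring nitrogen, so this is the first view of the aromatic ring carrying the chloro group. In this assay, bromo in place of chloro, ortho to a large group, gives a 1.3-fold higher number from compound 2 to compound 4 (0.10 log units; within the scatter), so the two compounds cannot be told apart here. No available measurement explains this result.

The compounds shown leave open what an amine, a methoxy group or a plain hydrogen at this place would give. They also leave open whether bromo and chloro would match with a benzyl group on the ring nitrogen.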